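The source may hold more compounds than are shown below. What is called first, only, known or untested is meant among the compounds shown, and "the series" means these compounds.

Compound 1, `CC1=CS[C@@](O)(c2ccc(Cl)cc2)c2noc(=O)n21`, gives 800 nM in a functional assay (Cavia porcellus) with Rattus norvegicus as the target; a lower number here means that less compound is needed, a higher number that more compound is needed for the effect.
Compound 2, `CC1=CS[C@@](O)(c2ccc(Br)cc2)c2noc(=O)n21`, gives 320 nM in this assay.
Compound 3, `C=CCOC1(c2ccc(Cl)cc2)SC=C(C)n2c1noc2=O`, gives 370 nM in this assay.

Compound 1 and compound 2 share a core and differ in one place: bromo in place of chloro on an aromatic carbon. That change gives a 2.5-fold lower number from compound 1 to compound 2 (0.40 log units; beyond the scatter). Compound 3 carries a different core; the difference between the two cores of compound 1 and compound 3 is not broken down here. Compound 2 and compound 3 give values that lie within the usual scatter of each other, so nothing is read from that pair. Compound 3 and compound 1 are further apart, with compound 1 the higher of the two.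

Compound 4, `C=CCOC1(c2ccc(Br)cc2)SC=C(C)n2c1noc2=O`, is not yet measured in this assay. It differs from compound 3 in one place: bromo in place of chloro on an aromatic carbon. This is the same change as from compound 1 to compound 2, made at the same place on the ring, and it occurs nowhere else among the compounds shown. With a single measured example of the change, the expectation for compound 4 rests on that one step alone, and the different core of compound 3 leaves open whether it carries over unchanged. For compound 4 the expected step is a 2.2-fold lower number from compound 3 to compound 4 (0.34 log units; beyond the scatter), because the same change gave a 2.5-fold lower number from compound 1 to compound 2 (0.40 log units; beyond the scatter). Compound 4 is therefore estimated at 170 nM, within a range of 80 nM to 370 nM.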

Compound 4, half-maximal effective concentration: 550 nM
Estimate against measurement, compound 4: 3.2-fold (0.51 log units) below; measured number above the stated range.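

On the core of compound 3, bromo in place of chloro gives a 1.5-fold higher number from compound 3 to compound 4 (0.17 log units; within the scatter) in this assay, so this pair cannot be told apart in this read-out. The step seen on the core of compound 1 therefore does not carry over at its measured size to the core of compound 3, and the two steps differ: the same change on two cores in this assay, a 2.5-fold lower number (0.40 log units; beyond the scatter) from compound 1 to compound 2 and a 1.5-fold higher number (0.17 log units; within the scatter) from compound 3 to compound 4, 3.7-fold (0.57 log units) apart, beyond the scatter of two such steps

For the compounds shown here, with only one pair on each core, this does not show which feature of the two cores sets the steps apart, and it gives no basis for predicting the same change on a further core.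

The compounds shown leave open how groups other than chloro and bromo, such as fluoro, methyl or a nitrile, would read on the aromatic carbon para to a large group on either core. Also open, from the compounds shown here alone, is whether the two cores would keep diverging with such groups, and how the same swap would read if a longer chain or an amine replaced the chain carried by compound 3.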